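Selenium to Sulfur Swap in a Methoxyphenyl Amide Series

The compounds below may be only part of what the source reports. "The series", "measured", "known", "first", "only" and "open" are said of these compounds alone.

Of the compounds shown here, two have been measured in a physicochemical assay for lipophilicity, read by HPLC, measured as octanol-water partition; a lower number here means a more polar compound, a higher number a more lipophilic compound. Compound 1 `COc1ccc(N(CC(=O)NCCC[Se]c2ccccc2)C(=O)/C=C/c2ccccc2)cc1` gives 3.7. Within the data shown here, compound 2 `COc1ccc(N(CC(=O)NCCC[Se]c2ccccc2)C(=O)CNC(=O)OC(C)(C)C)cc1` gives 3.3 and so stands lowest of the two numbers; the only measured step, a number 0.40 log units lower from compound 1 to compound 2 (beyond the scatter), places compound 2 below compound 1 by a modest amount that lies beyond the scatter.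

Compound 3 `COc1ccc(N(CC(=O)NCCCSc2ccccc2)C(=O)CNC(=O)OC(C)(C)C)cc1` has not yet been measured. It differs from compound 2 in one place: a group of 7 heavy atoms (6 carbon, 1 sulfur; one six-membered aromatic ring of carbon only) in place of a group of 7 heavy atoms (6 carbon, 1 selenium; one six-membered aromatic ring of carbon only), on a saturated chain carbon, three bonds along the chain from an amide-type nitrogen. Among the measured compounds shown here, the measured step between compound 1 and compound 2 concerns a different part of the molecule, the group on the carbonyl carbon, and leaves the chain end untouched, so no measured step bears directly on this swap of one chalcogen for another within an otherwise identical group. With nothing in the data to point either way, the step from compound 2 to compound 3 is expected to stay within the usual scatter, estimated as a number 0.20 log units lower from compound 2 to compound 3 (within the scatter) in this assay. Compound 3 is therefore estimated at 3.1, with a range from 2.7 to 3.5.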

Compound 3, partition coefficient: 3.12
Compound 3: middle estimate off by 0.02 log units, on the low side; the range from low to high includes it.
By their numbers in this assay, from the lowest: compounds 3 and 2 (each within the scatter of the next); then compound 1.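

Among these compounds, compound 3 gives the first reading at this position, on a saturated chain carbon, three bonds along the chain from an amide-type nitrogen. In this assay the exchange of the selenium-bearing group for phenylsulfanyl gives a number 0.18 log units lower from compound 2 to compound 3 (within the scatter), so this measurement does not separate the two atoms here, even though the computed counts give the entering group one hydrogen-bond acceptor and the leaving group none. The earlier change on the carbonyl carbon, by contrast, gave a number 0.40 log units lower from compound 1 to compound 2 (beyond the scatter), so among the compounds shown, only that change produced a difference that can be read beyond the scatter, and nothing at hand explains the result of the swap at the chain carbon.

The compounds shown leave open whether the same exchange would also stay within the scatter with the 2-phenylethenyl group of compound 1 on the carbonyl carbon. They also leave open how this assay would respond to a phenoxy group, which has oxygen in place of sulfur, to an amine or a carboxylic acid on that saturated chain carbon, or to a longer chain.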